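A few compounds are considered here, and "the series" means these few. Any claim that something is new, unique, unknown or untested is made for them only; others in the source may bear on it.

Values in a functional assay on MCF7 cells (Homo sapiens) for cytotoxicity (on this read-out higher numbers stand for weaker inhibition and lower numbers for stronger inhibition), for the three measured compounds:

Compound 1, `C=C/C=C\[C@H](C)[C@H](OC(N)=O)[C@@H](C)[C@H](O)[C@@H](C)C/C(C)=C\[C@H](C)[C@@H](O)[C@@H](C)/C=C\CCc1cccc(O)c1`: 130 nM
Compound 2, `C=C/C=C\[C@H](C)[C@H](OC(N)=O)[C@@H](C)[C@H](O)[C@@H](C)C/C(C)=C\[C@H](C)[C@@H](O)[C@@H](C)/C=C\CCc1ccsc1`: 850 nM
Compound 3, `C=C/C=C\[C@H](C)[C@H](OC(N)=O)[C@@H](C)[C@H](O)[C@@H](C)C/C(C)=C\[C@H](C)[C@@H](O)[C@@H](C)/C=C\CCc1ccc(C)c(O)c1`: 770 nM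

Compound 2 gives the highest of the three numbers in this assay. Its nearest neighbour is compound 3, and the two lie within the scatter, as a 1.1-fold lower number from compound 2 to compound 3 (0.04 log units; within the scatter) shows. Its furthest neighbour is compound 1, and that gap is beyond the scatter: a 6.5-fold higher number from compound 1 to compound 2 (0.82 log units; beyond the scatter).

Compound 4, `C=C/C=C\[C@H](C)[C@H](OC(N)=O)[C@@H](C)[C@H](O)[C@@H](C)C/C(C)=C\[C@H](C)[C@@H](O)[C@@H](C)/C=C\CCc1cc(F)cc(F)c1`, shares the whole core of compound 2 and differs from it in one place: 3,5-difluorophenyl in place of thiophen-3-yl on a saturated chain carbon, two bonds along the chain from a double-bonded chain carbon.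

Within the data shown here, two measured steps touch the same place. One is a 6.5-fold higher number from compound 1 to compound 2 (0.82 log units; beyond the scatter), where thiophen-3-yl enters in place of 3-hydroxyphenyl. The other is a 1.1-fold lower number from compound 2 to compound 3 (0.04 log units; within the scatter), where 3-hydroxy-4-methylphenyl replaces thiophen-3-yl. The ring that enters in compound 4, 3,5-difluorophenyl, carries no hydroxyl and no fluorine appears in any measured compound, so neither step maps onto it exactly. Both six-membered carbon rings seen so far gave numbers between those of compound 1 and compound 2, so a move back toward the lower end is plausible but uncertain.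

Compound 4 is therefore expected to land near the middle of the measured range, a step of a 1.9-fold lower number from compound 2 to compound 4 (0.28 log units; within the scatter), with an estimate of 450 nM in this assay, in a range from 130 nM to 1600 nM.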

Compound 4, half-maximal inhibitory concentration: 600 nM
Compound 4: middle estimate off by 1.3-fold (0.12 log units), on the low side; low and high end bracket the measured number.
By their numbers in this assay, from the lowest: compound 1; then compounds 4, 3 and 2 (each within the scatter of the next).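

In this assay, the 3,5-difluorophenyl ring that enters in compound 4 cannot be told apart from the rings already seen at this saturated chain position (a 1.4-fold lower number from compound 2 to compound 4 (0.15 log units; within the scatter); a 1.3-fold lower number from compound 3 to compound 4 (0.11 log units; within the scatter)). Both steps lie within the scatter, so a five-membered aromatic ring with a sulfur atom, a six-membered ring of carbon only with two fluorines, and the 3-hydroxy-4-methylphenyl ring all read alike here, and only the 3-hydroxyphenyl ring of compound 1 stands apart (a 4.6-fold higher number from compound 1 to compound 4 (0.66 log units; beyond the scatter)). Compound 4 thus shows that a ring without a hydroxyl reads the same as compound 3, which has one, so carrying a hydroxyl does not by itself set compound 1 apart, and nothing available offers a reason for this grouping.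

The compounds shown leave open whether the hydroxyl of compound 1 counts at all, as they include neither a plain phenyl ring nor a methoxy group in its place. They also leave open how an amine or a carboxylic acid on the ring, or a longer chain in place of the 2-(3,5-difluorophenyl)ethyl group, would read in this assay.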